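Swapping Pyrimidine Substituents on a Thiourea Growth Inhibitor

The compounds below may be only part of what the source reports. "The series", "measured", "known", "first", "only" and "open" are said of these compounds alone.

Of the compounds shown here, three have been tested in a functional assay on the whole organism for inhibition, with Chenopodium ficifolium as the target, with a stated time of 72 h, tested at 100 mg/L; a higher number here means more inhibition of growth at the concentration tested, a lower number less inhibition of growth. Compound 1 `COc1cc(SC)nc(NC(=S)NC(=O)c2c(-c3ccc(Cl)cc3Cl)noc2C)n1` gives 60.3%, the lowest of the three numbers. Compound 3 `COc1cc(SC)nc2n/c(=N/C(=O)c3c(-c4ccc(Cl)cc4Cl)noc3C)sn12` gives 68.3%, which lies within the scatter of compound 1, so the two cannot be told apart. Compound 2 `Cc1onc(-c2ccc(Cl)cc2Cl)c1C(=O)/N=c1/nc2nc(Cl)cc(C)n2s1` gives 73.6%, a number beyond the scatter above compound 1.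

Compound 4 `Cc1cc(Cl)nc(NC(=S)NC(=O)c2c(-c3ccc(Cl)cc3Cl)noc2C)n1` has not yet been measured. It differs from compound 1 in one place: 4-chloro-6-methylpyrimidin-2-yl in place of 4-methoxy-6-(methylsulfanyl)pyrimidin-2-yl on an amide-type nitrogen. Going by the values given here, no measured pair shows this change, so nothing here tells how large its effect is. With the shared core kept, the expectation is a step of modest size, possibly none beyond the scatter, in either direction. In this assay compound 4 is therefore estimated at 60%, with a range from 40% to 80%, which means an expected step of a number 0.3 percentage points lower from compound 1 to compound 4 (within the scatter).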

Compound 4, percent growth inhibition at one concentration: 48.3%
Compound 4: the middle estimate sits 11.7 percentage points above what was measured; the measured number falls inside the stated range.
By their numbers in this assay, from the lowest: compound 4; then compounds 1, 3 and 2 (each within the scatter of the next, the first and the last beyond it).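

Compound 1 and compound 4 form the first pair differing in one place, and in this assay 4-chloro-6-methylpyrimidin-2-yl in place of 4-methoxy-6-(methylsulfanyl)pyrimidin-2-yl gives a number 12 percentage points lower from compound 1 to compound 4 (beyond the scatter). The group on this amide-type nitrogen can therefore shift growth inhibition beyond the scatter, and this swap lowers it. No supporting measurement explains the step.

Because the whole group changes at once, the compounds shown leave open which part of it matters. From the compounds shown here alone, how a pyrimidine carrying an amine or an ethoxy group would behave here also remains open.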